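Swapping a chlorophenyl for a chlorothiophene on the ether arm

The source may hold more compounds than are shown below. What is called first, only, known or untested is meant among the compounds shown, and "the series" means these compounds.

Of the compounds shown here, three sharing one core have been measured in an assay on CHO cells for displacement of a labelled ligand from melanin-concentrating hormone receptor 1 (Rattus norvegicus), read by scintillation counting, with a stated time of 1 h; a higher number here means a weaker inhibitor, a lower number a stronger inhibitor. Compound 1 `Cn1c(C2CC2)nc2ccc(-n3ccc(OCc4ccc(F)cc4)cc3=O)cc21` gives 28 nM, compound 2 `CCn1c(C2CC2)nc2ccc(-n3ccc(OCc4ccc(Cl)cc4)cc3=O)cc21` gives 34 nM, and compound 3 `Cn1c(C2CC2)nc2ccc(-n3ccc(OCc4cccc(Cl)c4)cc3=O)cc21` gives 72 nM. Compound 3 therefore stands at the highest of the three numbers, the weakest inhibitor of the set. Within the data shown here, the one single-point step measured so far is a 2.6-fold higher number from compound 1 to compound 3 (0.41 log units; beyond the scatter), a modest move that worsens the number.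

Compound 4 `Cn1c(C2CC2)nc2ccc(-n3ccc(OCc4ccc(Cl)s4)cc3=O)cc21` differs from compound 3 by 5-chlorothiophen-2-yl in place of 3-chlorophenyl on a saturated chain carbon bound to an oxygen on an aromatic ring. Among the measured compounds shown here, no measured step covers an exchange of the six-membered ring itself for a five-membered one carrying sulfur; the step from compound 1 to compound 3 concerns only where the halogen sits on the same ring, so it bears on this change only loosely. With no direct guide, the expectation for this assay is a step that stays near compound 3, with some room for a slightly lower number. The step from compound 3 to compound 4 is estimated as a 1.4-fold lower number from compound 3 to compound 4 (0.16 log units; within the scatter). Compound 4 is accordingly expected to give about 50 nM, in the range from 15 nM to 160 nM.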

Compound 4, half-maximal inhibitory concentration: 11 nM
Compound 4: the middle estimate sits 4.5-fold (0.66 log units) above what was measured; measured number outside the range, below it.
By their numbers in this assay, from the lowest: compound 4; then compounds 1 and 2 (each within the scatter of the next); then compound 3.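

Among these compounds, until now, this place, on a saturated chain carbon bound to an oxygen on an aromatic ring, had held only halogen-bearing phenyl rings, and the one step there had raised the number in this assay. The new result shows that the ring itself can be exchanged: moving to a five-membered aromatic ring with sulfur gives a 6.5-fold lower number from compound 3 to compound 4 (0.82 log units; beyond the scatter), and the same group also beats the 4-fluorophenyl ring, with a 2.5-fold lower number from compound 1 to compound 4 (0.41 log units; beyond the scatter). No measurement at hand accounts for this gain, so it stands as an observation only.

As far as these compounds go, it remains open how much of the gain belongs to the sulfur ring and how much to its chlorine, a question that an unsubstituted thiophen-2-yl could help settle. From the compounds shown here alone, whether other five-membered rings, such as a furan or a thiazole, would behave alike is also open.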